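Methyl in Place of Fluoro on a Weak Aortic Inhibitor

This account rests on a few compounds, and the source may have more. Where it says the series, first, only, none or still open, it means among the compounds named here.

Compound 1 `CCOc1nc(-c2cc3ccccc3o2)cc(-c2cccc3ccccc23)c1C#N`: 344000 nM
Compound 2 `CCOc1nc(-c2cc3ccccc3o2)cc(-c2ccc(F)cc2)c1C#N`: 396000 nM

Of the compounds shown here, two sharing one core have been tested in a functional assay on aorta (strain Wistar) for inhibition, with Thoracic aorta (Rattus norvegicus) as the target; on this read-out lower numbers stand for stronger inhibition and higher numbers for weaker inhibition. Compound 1 gives 344000 nM in this assay, and compound 2 gives 396000 nM. Among the compounds with values here, both numbers are very high, and the only step between measured compounds, a 1.2-fold higher number from compound 1 to compound 2 (0.06 log units; within the scatter), lies within the scatter, so compound 2 stands level with compound 1 rather than apart from it.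

Compound 3 `CCOc1nc(-c2cc3ccccc3o2)cc(-c2ccc(C)cc2)c1C#N` is the next compound in this series and has not yet been measured. Its change from compound 2 is methyl in place of fluoro on an aromatic carbon. Within the data shown here, the one measured step that bears on it is the exchange at the same aromatic carbon, a 1.2-fold higher number from compound 1 to compound 2 (0.06 log units; within the scatter), which replaced naphthalen-1-yl with 4-fluorophenyl and left the number within the scatter. Among the measured compounds shown here, no measured step involves a methyl group, so the expectation rests on that single observation and on the small size of the change.

The step expected for compound 3 is a 1.0-fold higher number from compound 2 to compound 3 (0.00 log units; within the scatter), that is, none beyond the scatter. Compound 3 is therefore estimated at 400000 nM in this assay, with a range from 200000 nM to 800000 nM.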

Compound 3, half-maximal inhibitory concentration: 290000 nM
The estimate for compound 3 lay 1.4-fold (0.14 log units) above the measured number; the range from low to high includes it.
By their numbers in this assay, from the lowest: compounds 3, 1 and 2 (each within the scatter of the next).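

In this assay, the exchange of a single atom at the far end of the group, 4-fluorophenyl to 4-methylphenyl, gives a 1.4-fold lower number from compound 2 to compound 3 (0.14 log units; within the scatter) and so stays within the scatter. The earlier compounds shown here showed only the exchange of one whole aryl group for another at this aromatic carbon, whereas this result shows that fluoro and methyl, each on an aromatic carbon para to a large group, read level with each other. The comparison with the larger group gives a 1.2-fold lower number from compound 1 to compound 3 (0.07 log units; within the scatter) and also stays within the scatter, so naphthalen-1-yl, 4-fluorophenyl and 4-methylphenyl all stand level here, and all three numbers remain very high. No independent measurement is available to explain this flat result.

The compounds shown leave open whether an amine, a carboxylic acid or a hydroxyl group in the same place on the ring would move the number beyond the scatter. They also leave open whether any change elsewhere on the shared core would do so, since all three compounds differ only at this one position.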